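The source may hold more compounds than are shown below. What is called first, only, known or untested is meant among the compounds shown, and "the series" means these compounds.

Compound 1 `COc1ccc(CNC(=O)c2cc(-c3cncc(C)c3)ncc2-c2cnccn2)nc1OC` and compound 2 `COc1ccc(CNC(=O)c2cc(-c3cncc(C)c3)ncc2N2CCC2)nc1OC` share one core and differ at a single aromatic carbon. In an assay on CHO cells for antagonist activity at Orexin/Hypocretin receptor type 1 variant I408V (Homo sapiens), read by FLIPR, with a stated time of 5 min (a lower number here means a stronger inhibitor, a higher number a weaker inhibitor), compound 1 gives 10000 nM, and compound 2 gives 10000 nM. Among the measured compounds shown here, the only measured step, no change at the digits printed from compound 1 to compound 2 (within the scatter), leaves the read-out where it was. On these numbers compound 2 stands level with compound 1, the two not separated beyond the scatter.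

Compound 3 `COc1ccc(CNC(=O)c2cc(-c3cncc(C)c3)ncc2-c2cnn(C)c2)nc1OC` is not yet measured. It differs from compound 2 by 1-methyl-1H-pyrazol-4-yl in place of azetidin-1-yl on an aromatic carbon. For the measured compounds named here, the step from compound 1 to compound 2 is the one measured change at this same carbon that bears on the new substitution, and it showed no movement beyond the scatter, so no step beyond the scatter is expected in this assay from compound 2 to compound 3 in either direction. The estimate for compound 3 in this assay is 10000 nM, with an expected range from 3000 nM to 30000 nM. The step this estimate implies is expected to be no change at the digits printed from compound 2 to compound 3 (within the scatter).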

Compound 3, half-maximal inhibitory concentration: 10000 nM
Compound 3: the middle estimate sits on the measured number at the digits printed; the range from low to high includes it.
By their numbers in this assay, from the lowest: compounds 1, 2 and 3 (each within the scatter of the next).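

Against azetidin-1-yl, 1-methyl-1H-pyrazol-4-yl on this aromatic carbon in this assay gives no change at the digits printed from compound 2 to compound 3 (within the scatter) and against pyrazin-2-yl it gives no change at the digits printed from compound 1 to compound 3 (within the scatter) as well. A five-membered aromatic ring with 2 hetero atoms now reads alike with the four-membered non-aromatic ring of compound 2 and the pyrazin-2-yl group of compound 1, so three different groups at this position are not separated by this read-out. The data shown offer no explanation for this flat reading.

From the compounds shown here alone, whether a group of another kind here, such as a primary amine, a carboxylic acid or a longer alkyl chain, would separate from these three stays open. Also open, going by these compounds, is whether any change at this carbon can register while the rest of the shared core stays fixed.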